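Bromo in place of chloro on compound 3

This account rests on a few compounds, and the source may have more. Where it says the series, first, only, none or still open, it means among the compounds named here.

Measured in a functional assay on NCI-H460 cells (Homo sapiens) for cytotoxicity, read by sulforhodamine B assay, with a stated time of 3 days; a higher number here means a weaker inhibitor, a lower number a stronger inhibitor:
compound 1 `O=Cc1cn(Cc2cccc(Br)c2)c2ccccc12`: 39 nM
compound 2 `OCc1cn(Cc2cccc(F)c2)c2ccccc12`: 40 nM
compound 3 `OCc1cn(Cc2cccc(Cl)c2)c2ccccc12`: 19 nM

Compound 3, at 19 nM, has the lowest number of the three, and both others lie beyond the scatter from it. Compound 4 `OCc1cn(Cc2cccc(Br)c2)c2ccccc12` differs from compound 3 by one change, bromo in place of chloro on an aromatic carbon. For the measured compounds named here, only one measured step bears directly on this swap, the modest 2.1-fold lower number from compound 2 to compound 3 (0.32 log units; beyond the scatter), with chloro in place of fluoro on an aromatic carbon. Compound 1 also carries bromo but differs elsewhere, so it offers no clean comparison. One step fixes no trend, so the expected result in this assay is a 1.1-fold higher number from compound 3 to compound 4 (0.02 log units; within the scatter), nothing beyond the scatter. For compound 4 the estimated value is 20 nM, with an expected range of 9 nM to 42 nM.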

Compound 4, half-maximal inhibitory concentration: 28 nM
Beside the measured number, compound 4's estimate is 1.4-fold (0.15 log units) below it; the range from low to high includes it.
By their numbers in this assay, from the lowest: compounds 3, 4, 1 and 2 (each within the scatter of the next, the first and the last beyond it).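

In this assay, bromo on this aromatic carbon cannot be told apart from chloro (a 1.5-fold higher number from compound 3 to compound 4 (0.17 log units; within the scatter)) or from fluoro (a 1.4-fold lower number from compound 2 to compound 4 (0.15 log units; within the scatter)), even though chloro and fluoro themselves stand apart beyond the scatter. With bromo held fixed, hydroxymethyl and formyl also cannot be told apart (a 1.4-fold lower number from compound 1 to compound 4 (0.14 log units; within the scatter)). Nothing measured here accounts for these small steps.

Still open, from the compounds shown here alone, is whether a methoxy or an amine on this aromatic carbon would stay in the same range. Also open, going by these compounds, is how a carboxylic acid in place of hydroxymethyl would read.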